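From Bromo to Phenyl on the Aromatic Ring

The source may report more compounds than this note shows. Statements on the series, on what has been measured and on what is new or still open speak of the compounds shown alone.

In a functional assay on cells (Panel NCI-60 (60 carcinoma cell lines), Homo sapiens) for inhibition, read by colorimetric assay, with a stated time of 3 days (on this read-out lower numbers stand for stronger inhibition of growth and higher numbers for weaker inhibition of growth), compound 1 (`COc1ccc(NC(=O)CCCCCCNC(=O)C(O)(O)C(F)(F)F)cc1`) has the entry "not determined" (no result reported), so it offers no number for comparison. Compound 2 (`COc1ccc2sc(NC(=O)CCCCCCNC(=O)C(O)(O)C(F)(F)F)nc2c1`) gives 1230 nM, and compound 3 (`O=C(CCCCCCNC(=O)C(O)(O)C(F)(F)F)Nc1ccc(Br)cc1`) gives 3160 nM. Compound 3 therefore holds the higher of the two numbers, which means weaker inhibition of growth than compound 2, and the gap between them lies beyond the usual scatter.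

Compound 4 (`O=C(CCCCCCNC(=O)C(O)(O)C(F)(F)F)Nc1ccc(-c2ccccc2)cc1`) has not yet been measured. It carries phenyl in place of bromo on an aromatic carbon, para to a large group: phenyl in place of bromo on an aromatic carbon. For the measured compounds named here, no two measured compounds differ in only one place, so the data give no direct guide to the size of this swap. With compound 3 at 3160 nM as the closest reference, no change beyond the scatter is expected in this assay. The estimated move is a 1.3-fold lower number from compound 3 to compound 4 (0.10 log units; within the scatter), a small one with a wide margin of doubt. Compound 4 is expected at 2500 nM, within an estimated range from 800 nM to 6500 nM.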

Compound 4, concentration for 50% growth inhibition: 3090 nM
Compound 4: middle estimate off by 1.2-fold (0.09 log units), on the low side; the range from low to high includes it.
By their numbers in this assay, from the lowest: compound 2; then compounds 4 and 3 (each within the scatter of the next).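

Phenyl in place of bromo on an aromatic carbon, para to a large group, gives a 1.0-fold lower number from compound 3 to compound 4 (0.01 log units; within the scatter) in this assay and so provides the first comparison of compounds that differ in one place. For the compounds shown here, at this position, 6 heavy atoms and a six-membered aromatic ring of carbon only replace 1 bromine without a change beyond the scatter, which the earlier compounds could not show. Nothing available explains this result.

On these data alone, it remains open whether an amine or a carboxylic acid at this position would also leave the number within the scatter of compound 3. As far as these compounds go, it is also open whether the same swap would behave alike on the core of compound 2, or whether a longer chain would alter the picture.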